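Shortening a Chain: From Compound 1 to Compound 4

The source may hold more compounds than are shown below. What is called first, only, known or untested is meant among the compounds shown, and "the series" means these compounds.

Compound 1 `CCCCOS(=O)(=O)/C=C/c1ccc(OCCc2nc(-c3ccccc3)oc2C)cc1` was tested in an ADME assay on COS-7 cells (Chlorocebus aethiops) for cytotoxicity, read by MTT assay, with a stated time of 48 h; a higher number here means a weaker inhibitor, a lower number a stronger inhibitor. In this assay compound 1 gives > 100000 nM, which is a limit of the assay rather than a measured number. Compound 2 `CCOS(=O)(=O)/C=C/c1ccc(OCc2ccccc2)cc1OCCc1csc(-c2ccccc2)n1` gives > 100000 nM in this assay, also a limit. Compound 3 `CCOS(=O)(=O)/C=C/c1ccc(OCCCNc2nc(-c3ccccc3)cs2)cc1` likewise gives > 100000 nM in this assay, again a limit. So compound 1 stands exactly where the other two compounds stand: all three values sit at the limit of > 100000 nM in this assay, at which 3 of the 3 values shown sit, and none of them separates from the others.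

Compound 4 `CCOS(=O)(=O)/C=C/c1ccc(OCCc2nc(-c3ccccc3)oc2C)cc1` has not yet been measured in this assay. It differs from compound 1 in one place: hydrogen in place of ethyl on a saturated chain carbon, two bonds along the chain from an oxygen on an unsaturated carbon. Among the measured compounds shown here, no measured pair in this set differs in only one place, so there is no measured step to lean on; what the three values share is that none of them reaches far enough down to be read as a number.

For the measured compounds named here, the expected step is a step that the limit leaves unreadable from compound 1 to compound 4, which is to say no change beyond the scatter, because every value so far rests at the limit of > 100000 nM in this assay, at which 3 of the 3 values shown sit. Compound 4 is therefore expected to give 150000 nM, with a range from 80000 nM to 400000 nM, and most likely the assay will once more report only its limit.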

Compound 4, half-maximal inhibitory concentration: 84100 nM
Compound 4: the middle estimate sits 1.8-fold (0.25 log units) above what was measured, within the range that was stated.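

Among the compounds shown here, compound 4 is the first compound in this set to give a real number in this assay, 84100 nM, so cell toxicity can be read as a value here. For the compounds shown here, replacing the butoxy with an ethoxy gives the first step at this position, an at least 1.1-fold lower number from compound 1 to compound 4 (0.07 log units; that floor lies within the scatter), and that floor lies within the scatter, so the data do not establish that this change alone matters. The true size of the step could be small or considerably larger, and it stays unknown because compound 1 rests on a limit rather than a number: the limit of > 100000 nM in this assay, at which 3 of the 4 values shown sit.

Going by these compounds, what remains open is how the value moves along the series at this position, since a single pair cannot show whether a propyl, a methyl or a longer chain such as hexyl would give a number, or whether an amine at the end of the chain would behave differently. Compound 2 and compound 3 differ from compound 4 in more than one place, so they leave open whether the same change would give a similar result on another core.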